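This account rests on a few compounds, and the source may have more. Where it says the series, first, only, none or still open, it means among the compounds named here.

Two compounds from this study already have a result in a functional assay on the whole organism (strain Swiss) with Mus musculus as the target, in the maximal electroshock model, with a stated time of 1 h, at a dose of 300 mg/kg by the intraperitoneal route; a higher number here means a stronger effect of the compound at the dose given, a lower number a weaker effect. Compound 1, `CC(C(=O)N1CCN(c2ccc(Cl)cc2)CC1)N1C(=O)CCC1=O`, gives 0% in this assay. Compound 2, `CCC(C(=O)N1CCOCC1)N1C(=O)CCC1=O`, gives 0% in this assay. On these numbers compound 1 stands level with compound 2 at the digits shown, the two results lying within the usual scatter of each other, and neither compound shows any effect at the dose used. Compound 3, `CC(C(=O)N1CCN(c2cccc(Cl)c2)CC1)N1C(=O)CCC1=O`, has not yet been measured. It differs from compound 1 in a single place: 3-chlorophenyl in place of 4-chlorophenyl on an amine nitrogen in a ring. Among the measured compounds shown here, no pair of measured compounds differs in only one place, so there is no measured step of this kind to lean on. Because compound 1 gives 0% in this assay, the expected step is no change at the digits printed from compound 1 to compound 3 (within the scatter), that is none beyond the scatter. Compound 3 is therefore estimated at 0% in this assay, within a range from 0% to 10%.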

Compound 3, a percentage reported as activity, at one dose (the size of the read-out at that dose, not a potency): 75%
For compound 3 the middle estimate is 75 percentage points below the measured one, outside the stated range (above it).
By their numbers in this assay, from the lowest: compounds 1 and 2 (each within the scatter of the next); then compound 3.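

In this assay, putting 3-chlorophenyl in place of 4-chlorophenyl on the amine nitrogen in a ring gives a number 75 percentage points higher from compound 1 to compound 3 (beyond the scatter), although the two compounds have the same atoms. The earlier compounds shown here gave no sign that this position could matter, whereas this pair shows that the place of the chlorine on the phenyl group alone separates no effect from a clear effect at the dose given. Nothing shown here bears on why the two isomers differ.

On these data alone, it remains open whether the effect depends on chlorine itself or would also appear with 3-fluorophenyl, 3-methoxyphenyl or unsubstituted phenyl on the same nitrogen. The read-out also comes from a single dose, so it gives the size of the effect there and leaves the potency of compound 3 unknown.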